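The compounds below may be only part of what the source reports. "The series", "measured", "known", "first", "only" and "open" are said of these compounds alone.

In a functional assay on A549 cells (Homo sapiens) for antiproliferative activity, read by MTT assay, with a stated time of 48 h (on this read-out higher numbers stand for weaker inhibition and lower numbers for stronger inhibition), compound 1 (`CC[Si](CC)(CC)C/C1=C/C[C@](C)(CCC=C(C)C)/C=C/[C@@H](OC(=O)C=C(C)C)[C@](C)(O)/C=C/C1=O`) gives 3100 nM and compound 2 (`CO/N=C/C1=C/C[C@](C)(CCC=C(C)C)/C=C/[C@@H](OC(=O)C=C(C)C)[C@](C)(O)/C=C/C1=O`) gives 3470 nM with a 1.1-fold higher number from compound 1 to compound 2 (0.05 log units; within the scatter) as their step. Compound 3 (`CCN(CC)C(=O)/C1=C/C[C@](C)(CCC=C(C)C)/C=C/[C@@H](OC(=O)C=C(C)C)[C@](C)(O)/C=C/C1=O`) gives 11300 nM and stands highest of the three, with a 3.6-fold higher number from compound 1 to compound 3 (0.56 log units; beyond the scatter) and a 3.3-fold higher number from compound 2 to compound 3 (0.51 log units; beyond the scatter) as its steps. Compound 4 (`CC(C)=CCC[C@]1(C)/C=C/[C@@H](OC(=O)C=C(C)C)[C@](C)(O)/C=C/C(=O)/C(C(=O)N2CCCC2)=C\C1`) differs from compound 3 by pyrrolidin-1-yl in place of diethylamino on a carbonyl carbon and so turns diethylcarbamoyl into (pyrrolidin-1-yl)carbonyl. Among the compounds with values here, no measured step makes this swap. The nearest evidence is those two modest steps, which replace the whole group on the double-bonded ring carbon, whereas here the carbonyl stays. In this assay no step beyond the scatter is therefore expected, and the estimate is a 1.2-fold lower number from compound 3 to compound 4 (0.08 log units; within the scatter) for this change. Compound 4 is expected at 9500 nM with an estimated range from 4500 nM to 20000 nM as its likely span.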

Compound 4, half-maximal inhibitory concentration: 13000 nM
Estimate against measurement, compound 4: 1.4-fold (0.14 log units) below; the measured number falls inside the stated range.
By their numbers in this assay, from the lowest: compounds 1 and 2 (each within the scatter of the next); then compounds 3 and 4 (each within the scatter of the next).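

In this assay, closing diethylamino into the ring of pyrrolidin-1-yl on the carbonyl carbon gives a 1.2-fold higher number from compound 3 to compound 4 (0.06 log units; within the scatter), so this change of the amine part of the amide does not separate the two amides. The new amide stands apart from the other groups on the double-bonded ring carbon, as did compound 3, with a 3.7-fold higher number from compound 2 to compound 4 (0.57 log units; beyond the scatter) and a 4.2-fold higher number from compound 1 to compound 4 (0.62 log units; beyond the scatter). Nothing available explains these steps. The compounds shown leave open whether a morpholine amide, a secondary amide with its amide hydrogen or a carboxylic acid would keep the number of compound 4 or come closer to that of compound 1.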